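A hydroxyphenyl in place of a methoxyphenyl

A few compounds are considered here, and "the series" means these few. Any claim that something is new, unique, unknown or untested is made for them only; others in the source may bear on it.

In a functional assay on OVCAR-3 cells (Homo sapiens) for inhibition, read by MTT assay, with a stated time of 24 h (on this read-out lower numbers stand for stronger inhibition and higher numbers for weaker inhibition), compound 3 (`COc1ccccc1-n1cc(CN2C(=O)C[C@@H]3CC[C@@]2(C)C3(C)C)nn1`) gives 140 nM and compound 1 (`CC1(C)[C@H]2CC[C@]1(C)N(Cc1cn(-c3ccccc3Br)nn1)C(=O)C2`) gives 140 nM, level with each other. Compound 2 (`CC1(C)[C@H]2CC[C@]1(C)N(Cc1cn(-c3ccc(C#N)cc3)nn1)C(=O)C2`) gives 380 nM, the highest number. Unmeasured compound 4 (`CC1(C)[C@H]2CC[C@]1(C)N(Cc1cn(-c3cccc(O)c3)nn1)C(=O)C2`) carries 3-hydroxyphenyl in place of 2-methoxyphenyl on an aromatic nitrogen. Two measured steps on this aryl group bear on it. Methoxy in place of bromo gave no change at the digits printed from compound 1 to compound 3 (within the scatter), while 4-cyanophenyl in place of 2-bromophenyl gave a 2.7-fold higher number from compound 1 to compound 2 (0.43 log units; beyond the scatter). Neither step tests a hydroxyl group, so a modest rise is only tentatively expected, with an estimated 1.8-fold higher number from compound 3 to compound 4 (0.25 log units; within the scatter). For compound 4 the expected value is 250 nM, with an estimated range of 100 nM to 600 nM.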

Compound 4, half-maximal inhibitory concentration: 370 nM
Estimate against measurement, compound 4: 1.5-fold (0.17 log units) below; the measured number falls inside the stated range.
By their numbers in this assay, from the lowest: compounds 1 and 3 (each within the scatter of the next); then compounds 4 and 2 (each within the scatter of the next).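

In this assay a hydroxyl on the aryl group costs potency against both the 2-methoxyphenyl group (a 2.6-fold higher number from compound 3 to compound 4 (0.42 log units; beyond the scatter)) and the 2-bromophenyl group (a 2.6-fold higher number from compound 1 to compound 4 (0.42 log units; beyond the scatter)). Against the 4-cyanophenyl group the printed step stays within the scatter (a 1.0-fold lower number from compound 2 to compound 4 (0.01 log units; within the scatter)), so 3-hydroxyphenyl and 4-cyanophenyl cannot be told apart here. Nothing measured here accounts for these steps. The step from compound 3 changes both the group and its place on the phenyl ring, and the two effects remain unseparated. From the compounds shown here alone, whether 2-hydroxyphenyl, or an amine or carboxylic acid on the phenyl ring, would match compound 3 remains open.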